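This account rests on a few compounds, and the source may have more. Where it says the series, first, only, none or still open, it means among the compounds named here.

Measured so far in a toxicity assay on HEK-293T cells (Homo sapiens) for cytotoxicity, read by MTT assay, with a stated time of 72 h; on this read-out higher numbers stand for weaker inhibition and lower numbers for stronger inhibition:

compound 1 `CN(C)CCCCCn1c2c(c3ccccc31)C(=O)c1c[n+]([O-])c3ccccc3c1C2=O`: 70 nM
compound 2 `O=C1c2c[n+]([O-])c3ccccc3c2C(=O)c2c1c1ccccc1n2Cc1cn([C@@H]2C[C@H](O)[C@@H](CO)O2)nn1`: 820 nM
compound 3 `O=C1c2c[n+]([O-])c3ccccc3c2C(=O)c2c1c1ccccc1n2Cc1cn(CC(O)CO)nn1`: 760 nM

Compound 1 has the lowest of the three numbers, so it is the most cytotoxic of the measured set. Compound 4 `CN1CCN(CCCCn2c3c(c4ccccc42)C(=O)c2c[n+]([O-])c4ccccc4c2C3=O)CC1` is still to be measured. Its change from compound 1 is 4-methylpiperazin-1-yl in place of (dimethylamino)methyl on a saturated chain carbon, four bonds along the chain from an aromatic nitrogen.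

The nearest measured evidence is an 11-fold higher number from compound 1 to compound 3 (1.04 log units; beyond the scatter), a large step at the same chain. That step removes the whole 4-(dimethylamino)butyl group, however, whereas compound 4 keeps a chain ending in an amine, so it sets an outer bound rather than a guide. The other step, a 1.1-fold lower number from compound 2 to compound 3 (0.03 log units; within the scatter), lies within the scatter and concerns a different part of the side chain, so it says little here. Within the data shown here, no measured pair exchanges one amine end group for another. A small rise at most is therefore expected, probably close to the scatter and well short of the large step. The expected step is a 1.6-fold higher number from compound 1 to compound 4 (0.20 log units; within the scatter). For compound 4 the estimate is 110 nM, with an expected range of 35 nM to 350 nM.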

Compound 4, half-maximal inhibitory concentration: 100 nM
Beside the measured number, compound 4's estimate is 1.1-fold (0.04 log units) above it; the range from low to high includes it.
By their numbers in this assay, from the lowest: compounds 1 and 4 (each within the scatter of the next); then compounds 3 and 2 (each within the scatter of the next).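

Notes on the chain end, on a saturated chain carbon, four bonds along the chain from an aromatic nitrogen: in this assay the exchange of (dimethylamino)methyl for 4-methylpiperazin-1-yl gives a 1.4-fold higher number from compound 1 to compound 4 (0.15 log units; within the scatter) and is the first direct comparison of one amine end group with another, showing that this larger ring-bearing end leaves the number within the scatter of the open-chain dimethylamino end. The change from the triazole side chain to 3-(4-methylpiperazin-1-yl)propyl gives a 7.6-fold lower number from compound 3 to compound 4 (0.88 log units; beyond the scatter) in the same assay, so the gap first seen for compound 1 against compound 3 also appears with a second amine-ended chain, and the low number is not confined to the 4-(dimethylamino)butyl group. No measured evidence accompanies these compounds that would account for either step.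

Two amine ends cannot settle whether the nitrogen at the chain end is required, and a chain of the same length ending in a hydroxyl group or in morpholin-4-yl would put that to the test. On these data alone, the effect of chain length also remains open, and a longer or shorter chain carrying 4-methylpiperazin-1-yl would address it.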